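Methoxy on the aryl ring of a methylene lactone series

The compounds below may be only part of what the source reports. "The series", "measured", "known", "first", "only" and "open" are said of these compounds alone.

Three members of the series have numbers in a functional assay on BXPC-3 cells (Homo sapiens) for cytotoxicity, read by MTT assay, with a stated time of 72 h, tested at 10 uM; a higher number here means a weaker effect of the compound at the concentration tested, a lower number a stronger effect. Compound 1 `C=C1CC(c2ccccc2)OC1=O` gives 136%, compound 2 `C=C1C(=O)O[C@@H](c2ccccc2)[C@H]1C` gives 41%, and compound 3 `C=C1C(=O)O[C@@H](C(C)C)[C@H]1C` gives 153%. Compound 2 has the lowest number of the three, so the strongest effect at the concentration tested; the nearest is compound 1, whose number is higher by an amount beyond the scatter, and compound 3 lies further away still, also beyond the scatter. Compounds 1 and 3 lie within the scatter of each other, so no order between them is claimed.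

The next compound, compound 4 `C=C1C(=O)O[C@@H](c2ccc(OC)cc2)[C@H]1C`, keeps the whole frame of compound 2 and changes it in one place: methoxy in place of hydrogen on an aromatic carbon, on an aromatic carbon of a six-membered aromatic ring of carbon only. No measured pair in the series shows a change of this kind, so the size of the step cannot be read from other pairs. In this assay the step is expected to stay within the scatter, or at most to move the number slightly upward. Compound 4 is therefore estimated at 50%, with a range from 25% to 85%, which would mean an expected step of a number 9 percentage points higher from compound 2 to compound 4 (within the scatter).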

Compound 4, a percentage reported as activity, at one concentration (the size of the read-out at that concentration, not a potency): 13%
For compound 4 the middle estimate is 37 percentage points above the measured one, and the stated range ends above it.
By their numbers in this assay, from the lowest: compound 4; then compound 2; then compound 1; then compound 3.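

In this assay, methoxy in place of hydrogen on an aromatic carbon, para to a group of 8 heavy atoms, comes with a number 28 percentage points lower from compound 2 to compound 4 (beyond the scatter), and the direction is towards a stronger effect at the concentration tested. For the compounds shown here, this is the first step that can be read across a single place, as the earlier compounds offered no pair differing in one place only. It shows that this position on the six-membered aromatic ring tolerates a substituent in this assay without loss of effect, and that a change here can move the number by more than the usual scatter. Nothing at hand bears on why the number falls with this change.

The compounds shown leave open whether a hydroxyl group, a fluorine atom or a longer chain such as ethoxy at the same position would move the number in the same direction, and whether methoxy on another carbon of the ring would do so. Also open, as far as these compounds go, is whether the same change would have a similar effect on the frame of compound 1 or would depend on the rest of compound 2.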